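Aminohexyl chain in place of aminophenyl on the core

This account rests on a few compounds, and the source may have more. Where it says the series, first, only, none or still open, it means among the compounds named here.

Compound 1 `Nc1cccc(Nc2c(C(=O)NCc3ccc(F)cc3)nc(Br)c3cccnc23)c1` carries the 3-aminophenyl group on a nitrogen on an aromatic ring of the shared core. In a functional assay on SK-BR-3 cells (Homo sapiens) for cytotoxicity, read by MTT assay, with a stated time of 72 h (on this read-out lower numbers stand for stronger inhibition and higher numbers for weaker inhibition), compound 1 gives only a limit, > 10000 nM. This value sits at the limit of > 10000 nM in this assay, at which 1 of the 2 values shown sits, so compound 1 is placed no more closely than at the weak end of the series. Compound 2 `N[C@H]1CC[C@H](Nc2c(C(=O)NCc3ccc(Cl)cc3Cl)nc(Br)c3cccnc23)CC1` differs from compound 1 in several places; in this assay compound 2 gives 6000 nM. Among the compounds with values here, no single-change step joins the two, so their numbers stand side by side only. Compound 3 `NCCCCCCNc1c(C(=O)NCc2ccc(F)cc2)nc(Br)c2cccnc12` is not yet measured. It differs from compound 1 in one place: 6-aminohexyl in place of 3-aminophenyl on a nitrogen on an aromatic ring. Within the data shown here, no measured pair shows whether the loss of the six-membered aromatic ring for a chain with no ring is tolerated; the only measured compound without an aromatic group at that nitrogen is compound 2, and its value is weak. The expected step of an at least 1.2-fold lower number from compound 1 to compound 3 (0.09 log units; that floor lies within the scatter) is small, toward stronger inhibition if anything, and may not exceed the scatter. Compound 3 is estimated at 8000 nM, with a range from 2500 nM to 25000 nM, and a real chance that only a limit is returned.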

Compound 3, half-maximal inhibitory concentration: 3000 nM
Compound 3: the middle estimate sits 2.7-fold (0.43 log units) above what was measured; measured number inside the range.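

With this assay the series gains its first single-change step at this nitrogen on an aromatic ring, an at least 3.3-fold lower number from compound 1 to compound 3 (0.52 log units; beyond the scatter) and this step lies beyond the scatter, so a chain with no ring is tolerated here in place of the six-membered aromatic ring of 3-aminophenyl. The 3-aminophenyl group is therefore not needed at this place for a measurable value on the core of compound 1, although this reading rests on a single pair. On these data alone, compound 1 gives a limit, > 10000 nM and not a number, so only a floor of the step can be read and its true size stays unknown: the limit of > 10000 nM in this assay, at which 1 of the 3 values shown sits.

As far as these compounds go, it remains open whether the terminal amine of 6-aminohexyl contributes to the change, which a chain ending in a hydroxyl or a methyl group would test, and whether a shorter or longer chain would move the number. Compound 2 differs from compound 3 in several places and gives no read on how a saturated ring at this nitrogen compares with the chain.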